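Ethoxy for Bromo on the Anilino Ring of Compound 2

This account rests on a few compounds, and the source may have more. Where it says the series, first, only, none or still open, it means among the compounds named here.

Compound 1 `Cc1nc2c([nH]1)C(=O)/C(=N/c1ccc(F)cc1F)C(Cl)=C2O`: 1200 nM
Compound 2 `O=C1C=C(Nc2ccc(Br)cc2)C(=O)c2[nH]c(-c3ccccn3)nc21`: 12000 nM

In an ADME assay (Rattus norvegicus) for inhibition (a higher number here means a weaker inhibitor, a lower number a stronger inhibitor), compound 2 gives 12000 nM, the highest of the two numbers measured, and its nearest neighbour is compound 1 with 1200 nM, a gap that lies beyond the scatter. Compound 3 `CCOc1ccc(NC2=CC(=O)c3nc(-c4ccccn4)[nH]c3C2=O)cc1` is not yet measured. It differs from compound 2 by ethoxy in place of bromo on an aromatic carbon, placed para to a large group. Going by the values given here, no step between measured compounds shows what this exchange does, so only a modest step is expected in this assay, with no clear direction. Compound 3 is estimated at 10000 nM, within 3000 nM to 40000 nM, an expected step of a 1.2-fold lower number from compound 2 to compound 3 (0.08 log units; within the scatter).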

Compound 3, half-maximal inhibitory concentration: 6500 nM
Beside the measured number, compound 3's estimate is 1.5-fold (0.19 log units) above it, within the range that was stated.
By their numbers in this assay, from the lowest: compound 1; then compounds 3 and 2 (each within the scatter of the next).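

In this assay the exchange of 4-bromophenyl for 4-ethoxyphenyl gives a 1.8-fold lower number from compound 2 to compound 3 (0.27 log units; within the scatter) and so leaves compound 2 and compound 3 indistinguishable. At this position, then, a single bromine atom and an ethoxy group of three heavy atoms, one of them a hydrogen-bond acceptor, give matching results. Whether an amine, a carboxylic acid or a longer alkoxy chain would also match at this position remains open, and nothing measured here accounts for the result.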